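A few compounds are considered here, and "the series" means these few. Any claim that something is new, unique, unknown or untested is made for them only; others in the source may bear on it.

Compound 1 `NCC(O)CNc1cc(N2Cc3ccccc3C2)nc2ccccc12`: 2900 nM
Compound 2 `Cc1ccc2nc(N3CCCc4ccc(F)cc4C3)cc(NC(C)(C)CN)c2c1`: 25000 nM

In an ADME assay on HEp-2 cells (Homo sapiens) for cytotoxicity, read by CCK-8 assay, with a stated time of 5 days (on this read-out higher numbers stand for lower toxicity in this test and lower numbers for higher toxicity in this test), compound 2 stands at the highest of the two numbers, and compound 1 is set apart from it by a gap beyond the usual scatter. Compound 3 `Cc1ccc2nc(N3CCCc4ccc(F)cc4C3)cc(NC3(CN)COC3)c2c1` differs from compound 2 only in one group: 3-(aminomethyl)oxetan-3-yl in place of 1-(aminomethyl)-1-methylethyl on a nitrogen on an aromatic ring. For the measured compounds named here, no measured pair shows this exchange, so the expected step is none beyond the scatter, in no fixed direction. Compound 3 is therefore expected to give 25000 nM, within a range from 10000 nM to 60000 nM. The estimated step is no change at the digits printed from compound 2 to compound 3 (within the scatter).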

Compound 3, half-maximal cytotoxic concentration: 86000 nM
Estimate against measurement, compound 3: 3.4-fold (0.54 log units) below; measured number outside the range, above it.
By their numbers in this assay, from the lowest: compound 1; then compound 2; then compound 3.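

Placing 3-(aminomethyl)oxetan-3-yl instead of 1-(aminomethyl)-1-methylethyl on the nitrogen gives a 3.4-fold higher number from compound 2 to compound 3 (0.54 log units; beyond the scatter) in this assay, so this position responds to the exchange, toward lower toxicity in this test. Compound 1 and compound 2 differ in more than one place, so they could not show this. No measurement given here accounts for the step.

On these data alone, what a cyclobutane or azetidine ring would give in the same place remains open. So does whether the exchange would have the same effect on the core of compound 1.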